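Swapping bromo for pentyl on the aryl triazole

This account rests on a few compounds, and the source may have more. Where it says the series, first, only, none or still open, it means among the compounds named here.

Three compounds share a core and differ only in the group on the triazole. Compound 1 `O=c1cc(Cn2cc(C3CC3)nn2)c2ccc(O)cc2o1` carries a cyclopropyl there; in a functional assay on HepG2 cells (Homo sapiens) for inhibition, read by MTT assay, with a stated time of 72 h (a lower number here means a stronger inhibitor, a higher number a weaker inhibitor), compound 1 gives only a limit, > 100000 nM. Compound 2 `O=c1cc(Cn2cc(CCO)nn2)c2ccc(O)cc2o1` carries a 2-hydroxyethyl; in this assay compound 2 likewise gives a limit, > 100000 nM. For the measured compounds named here, compound 3 `O=c1cc(Cn2cc(-c3ccc(Br)cc3)nn2)c2ccc(O)cc2o1` carries a 4-bromophenyl, and in this assay compound 3 gives 61100 nM, the only number among the three values. The steps of an at least 1.6-fold lower number from compound 1 to compound 3 (0.21 log units; that floor lies within the scatter) and an at least 1.6-fold lower number from compound 2 to compound 3 (0.21 log units; that floor lies within the scatter) have floors within the scatter, and the step that the two limits leave unreadable from compound 1 to compound 2 cannot be read, since two of the three values sit at the limit (the limit of > 100000 nM in this assay, at which 2 of the 3 values shown sit).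

Compound 4 `CCCCCc1ccc(-c2cn(Cc3cc(=O)oc4cc(O)ccc34)nn2)cc1` differs from compound 3 by pentyl in place of bromo on an aromatic carbon. Going by the values given here, no measured step changes a substituent on that phenyl, so nothing among the steps speaks to the size of this one. Compound 4 is therefore expected to give a number close to that of compound 3, with a step of a 1.4-fold lower number from compound 3 to compound 4 (0.13 log units; within the scatter) no larger than the scatter, and the estimate for compound 4 is 45000 nM, between 10000 nM and 150000 nM.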

Compound 4, half-maximal inhibitory concentration: 27300 nM
Compound 4: middle estimate off by 1.6-fold (0.22 log units), on the high side, and the stated range covers the measured number.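

In this assay, a 2.2-fold lower number from compound 3 to compound 4 (0.35 log units; beyond the scatter) is the only step shown whose size can be read and lies beyond the scatter. For the compounds shown here, it shows that the number responds to a change on an aromatic carbon of the six-membered ring, para to a large group, even with the triazole and the phenyl left in place, a position that no earlier step touched. The steps among the groups on the triazole give no such reading, and the step from compound 1 to compound 2 cannot be read: the limit of > 100000 nM in this assay, at which 2 of the 4 values shown sit.

The compounds shown leave open whether a longer chain, a shorter chain such as methyl, an amine or a carboxylic acid at this position would lower the number further or raise it. A single step also cannot separate the effect of removing bromo from that of adding pentyl.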